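The source may hold more compounds than are shown below. What is called first, only, known or untested is meant among the compounds shown, and "the series" means these compounds.

Compound 1 `O=C(/C(=C\c1ccc(O)cc1O)Sc1ccc(Br)cc1)c1ccc(Cl)cc1`: 50000 nM
Compound 2 `O=C(/C(=C\c1ccc(O)cc1O)SCc1ccc(Cl)cc1)c1ccc(Cl)cc1`: 50000 nM
Compound 3 `O=C(/C(=C\c1ccc(O)cc1O)Sc1ccccc1Br)c1ccc(Cl)cc1`: 50000 nM

In a functional assay on DU-145 cells (Homo sapiens) for inhibition, read by trypan blue exclusion, with a stated time of 96 h (a lower number here means a stronger inhibitor of growth, a higher number a weaker inhibitor of growth), compound 1 gives 50000 nM, level with compound 2 and compound 3: the steps of no change at the digits printed from compound 1 to compound 2 (within the scatter) and no change at the digits printed from compound 1 to compound 3 (within the scatter) show no movement, and no change at the digits printed from compound 2 to compound 3 (within the scatter) likewise. Compound 4 `COc1ccc(/C=C(/Sc2ccc(Br)cc2)C(=O)c2ccc(Cl)cc2)cc1` differs from compound 1 in another place: 4-methoxyphenyl in place of 2,4-dihydroxyphenyl on a double-bonded chain carbon bound to a double-bonded chain carbon. Going by the values given here, none of the measured steps touches the group on the double-bonded chain carbon, so they cannot say how this change acts; they only show that the measured series sits at one level in this assay. The step of no change at the digits printed from compound 1 to compound 4 (within the scatter) is therefore expected to stay within the scatter. Compound 4 is estimated at 50000 nM, with a range of 15000 nM to 100000 nM.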

Compound 4, concentration for 50% growth inhibition: 50000 nM
Compound 4: the middle estimate sits on the measured number at the digits printed; the range from low to high includes it.
By their numbers in this assay, from the lowest: compounds 1, 2, 3 and 4 (each within the scatter of the next).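

In this assay, going by these compounds alone, the step of no change at the digits printed from compound 1 to compound 4 (within the scatter) is the first reading at the double-bonded chain carbon bound to a double-bonded chain carbon, as the earlier steps changed only the group on sulfur. Here 4-methoxyphenyl, with 0 hydrogen-bond donors, stands level with 2,4-dihydroxyphenyl, with 2, so removing both donors leaves the growth-inhibition reading unmoved. No measured evidence bears on this result. On these data alone, whether an aminophenyl or a carboxyphenyl group at this place would shift the reading from the level shared by all four compounds remains open.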